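The source may report more compounds than this note shows. Statements on the series, on what has been measured and on what is new or still open speak of the compounds shown alone.

In a functional assay on CCRF-CEM cells (Homo sapiens) for inhibition (a higher number here means that more compound is tolerated, a lower number that less compound is tolerated), compound 3, `O=C1c2ccccc2N(Cc2ccccc2Cl)S(=O)(=O)N1COCc1ccccc1`, gives 22200 nM, the lowest of the three numbers measured. Compound 1, `O=C1c2ccccc2N(COCc2ccccc2)S(=O)(=O)N1COCc1ccccc1`, stands nearest to it: in this assay compound 1 gives 27700 nM, and the step of a 1.2-fold lower number from compound 1 to compound 3 (0.10 log units; within the scatter) lies within the scatter. Compound 2, `O=C1c2ccccc2N(Cc2ccccc2)S(=O)(=O)N1Cc1ccccc1`, stands furthest away; in this assay compound 2 gives 108000 nM, a gap from compound 3 that lies beyond the scatter.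

Compound 4, `O=C1c2ccccc2N(Cc2ccccc2)S(=O)(=O)N1COCc1ccccc1`, differs from compound 3 in one place: hydrogen in place of chloro on an aromatic carbon. Going by the values given here, no measured pair shows this removal of a chloro on its own. Among the compounds with values here, the only measured step that touches this part of the molecule, a 1.2-fold lower number from compound 1 to compound 3 (0.10 log units; within the scatter), exchanged a whole benzyloxy for a 2-chlorophenyl and stayed within the scatter, which suggests that changes on this carbon have not moved the number much here. Compound 2, with benzyl on both nitrogens, gave a higher number, but it differs from compound 4 in the other substituent and so bears on it only loosely.

Compound 4 is therefore expected to show a step of a 1.4-fold higher number from compound 3 to compound 4 (0.13 log units; within the scatter), with no change beyond the scatter. The estimate for compound 4 in this assay is 30000 nM, in a range from 12000 nM to 75000 nM.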

Compound 4, half-maximal cytotoxic concentration: 100000 nM
The estimate for compound 4 lay 3.3-fold (0.52 log units) below the measured number, and the stated range ends below it.
By their numbers in this assay, from the lowest: compounds 3 and 1 (each within the scatter of the next); then compounds 4 and 2 (each within the scatter of the next).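

Going by these compounds alone, compound 3 and compound 4 isolate the chloro for the first time: in this assay, hydrogen in place of chloro on the aromatic carbon, ortho to a large group, gives a 4.5-fold higher number from compound 3 to compound 4 (0.65 log units; beyond the scatter) and so more compound is tolerated without it. The earlier near-match of compound 1 and compound 3 had hidden this, and the new pairs show that each of these two compounds differs from compound 4 by a change that matters, since phenyl in place of benzyloxy on the chain carbon bound to the sulfonamide nitrogen gives a 3.6-fold higher number from compound 1 to compound 4 (0.56 log units; beyond the scatter) as well. On the chain carbon bound to the amide-type nitrogen, the exchange of benzyloxy for phenyl shows no such effect, with a 1.1-fold lower number from compound 2 to compound 4 (0.03 log units; within the scatter) and so no difference beyond the usual scatter.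

As far as these compounds go, whether a bromo, a methyl or an amine on that aromatic carbon would give a number like that of the chloro stays open, as does whether the chloro would count in the same way with benzyl on both nitrogens. Nothing available here explains why the chloro matters in these cells.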